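The source may hold more compounds than are shown below. What is called first, only, known or untested is meant among the compounds shown, and "the series" means these compounds.

For the measured compounds named here, compound 2 `Cn1c(Cc2nn(C)c(=O)c3ccccc23)nnc1SCC(=O)Nc1ccc(Cl)cc1Cl` is the only compound of this set with an actual number in an assay on isolated protein (Mus musculus) for inhibition of IL15-IL15 receptor (Homo sapiens), read by resazurin assay, with stated times of 30 min and 2.5 days; on this read-out higher numbers stand for weaker inhibition and lower numbers for stronger inhibition: in that assay compound 2 gives 17300 nM. Compound 1 `CCCOc1ccc(NC(=O)CSc2nnc(Cc3nn(C)c(=O)c4ccccc34)n2C)cc1` stands at a limit of the assay, > 30000 nM. Going by the values given here, the one measured step, an at least 1.7-fold lower number from compound 1 to compound 2 (0.23 log units; that floor lies within the scatter), starts from that limit of > 30000 nM in this assay, at which 1 of the 2 values shown sits, and so its size is itself only a floor. Compound 3 `Cn1c(Cc2nn(C)c(=O)c3ccccc23)nnc1SCC(=O)Nc1ccc(F)cc1F` has not been measured. It differs from compound 2 in one place: 2,4-difluorophenyl in place of 2,4-dichlorophenyl on an amide-type nitrogen. Among the compounds with values here, no measured step exchanges one substituent for another on the amide-type nitrogen, and the only step at hand is the floor an at least 1.7-fold lower number from compound 1 to compound 2 (0.23 log units; that floor lies within the scatter). With so little to go on, no change beyond the scatter is expected, and a drift towards weaker inhibition is as plausible as none. The expected step from compound 2 to compound 3 is a 1.4-fold higher number from compound 2 to compound 3 (0.16 log units; within the scatter). Compound 3 is therefore estimated at 25000 nM in this assay, with a range from 10000 nM to 60000 nM.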

Compound 3, half-maximal inhibitory concentration: "not active" (no number reported)
No number was reported for compound 3; there is nothing to compare the estimate with.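

Compound 3 is reported only as "not active" in this assay, without a number, and no new step can be read between compound 2 and compound 3. Left open is how far inhibition shifts with 2,4-difluorophenyl in place of 2,4-dichlorophenyl, and how compounds compare at the edge of the measurable range: the limit of > 30000 nM in this assay, at which 1 of the 3 values shown sits.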